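Benzimidazole Amide in an Indoleamine Dioxygenase Series

A few compounds are considered here, and "the series" means these few. Any claim that something is new, unique, unknown or untested is made for them only; others in the source may bear on it.

Three compounds share one core and differ only in the ring attached to the carbonyl carbon of the amide. Compound 1 `O=C(NCc1cccc(Cn2cnc3ccccc32)c1)c1cc2ccccc2o1` carries a benzofuran, and in an assay for inhibition of Indoleamine 2,3-dioxygenase 1 (Homo sapiens), read by HPLC, with a stated time of 48 h (a lower number here means a stronger inhibitor, a higher number a weaker inhibitor), compound 1 gives 413 nM. Compound 2 `O=C(NCc1cccc(Cn2cnc3ccccc32)c1)c1cc2ccccc2[nH]1` carries an indole, and in this assay compound 2 gives 72 nM, a 5.7-fold lower number from compound 1 to compound 2 (0.76 log units; beyond the scatter). Compound 3 `O=C(NCc1cccc(Cn2cnc3ccccc32)c1)c1cc2cc(O)ccc2[nH]1` carries the same indole with a hydroxy group added, and in this assay compound 3 gives 781 nM; an 11-fold higher number from compound 2 to compound 3 (1.04 log units; beyond the scatter), while a 1.9-fold higher number from compound 1 to compound 3 (0.28 log units; within the scatter), so compound 3 and compound 1 cannot be told apart.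

Compound 4 `O=C(NCc1cccc(Cn2cnc3ccccc32)c1)c1nc2ccccc2[nH]1` is the next change: 1H-benzimidazol-2-yl in place of 5-hydroxy-1H-indol-2-yl on a carbonyl carbon. Two things happen at once: the hydroxy group leaves together with the indole, and a benzimidazole enters. The hydroxy part is covered by the step from compound 2 to compound 3, which read backwards would point to a large drop in the number. Among the measured compounds shown here, no measured step covers the move from indole to benzimidazole, so that part is unknown. Weighing the known large effect against the unknown one, a lower number than compound 3 is expected, a 3.9-fold lower number from compound 3 to compound 4 (0.59 log units; beyond the scatter). Compound 4 is therefore estimated at 200 nM in this assay, with a range from 50 nM to 800 nM.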

Compound 4, half-maximal inhibitory concentration: 407 nM
The estimate for compound 4 lay 2.0-fold (0.31 log units) below the measured number; the measured number falls inside the stated range.
By their numbers in this assay, from the lowest: compound 2; then compounds 4, 1 and 3 (each within the scatter of the next).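

In this assay, the move from a ring with one hetero atom to the 1H-benzimidazol-2-yl ring, whose five-membered ring holds two hetero atoms, gives a 5.7-fold higher number from compound 2 to compound 4 (0.75 log units; beyond the scatter), so this second ring nitrogen does not keep the level of the plain indole. Compound 4 cannot be told apart from the other two compounds, with a 1.0-fold lower number from compound 1 to compound 4 (0.01 log units; within the scatter) and a 1.9-fold lower number from compound 3 to compound 4 (0.28 log units; within the scatter), and so three different changes to the indole of compound 2 (benzofuran, added hydroxy, benzimidazole) all end at one shared level, leaving compound 2 alone as the strongest inhibitor of the four. Nothing available explains why these three rings land together or why the indole stands apart.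

As far as these compounds go, all four compounds keep an unbranched fused ring pair on the carbonyl carbon, so it remains open whether the loss seen with the hydroxy group would also follow from a methoxy group or a fluorine in its place. From the compounds shown here alone, the effect of a group such as an amine or a carboxylic acid on the benzimidazole ring of compound 4 also remains open.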